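A Fluoro Substituent Added to an Inactive Series

This account rests on a few compounds, and the source may have more. Where it says the series, first, only, none or still open, it means among the compounds named here.

Compound 1, `Cc1ccc2nc(Nc3nc(Nc4ccc(S(N)(=O)=O)cc4)ncc3C)sc2c1`, in a functional assay on MCF7 cells (Homo sapiens) for antiproliferative activity, read by MTT assay, with a stated time of 48 h (on this read-out lower numbers stand for stronger inhibition and higher numbers for weaker inhibition), reaches only the limit > 50000 nM.
Compound 2, `CS(=O)(=O)c1ccc(Nc2nccc(Nc3nc4ccc(F)cc4s3)n2)cc1`, in this assay reaches only the limit > 60000 nM.
Compound 3, `Cc1cnc(Nc2ccc(Cl)cc2)nc1Nc1nc2ccccc2s1`, in this assay reaches only the limit > 50000 nM.

None of the three measured compounds gives a number in this assay; each is reported at a limit of the assay. Compound 2 sits at the limit of > 60000 nM in this assay, at which 1 of the 3 values shown sits, while compound 1 and compound 3 sit at the limit of > 50000 nM in this assay, at which 2 of the 3 values shown sit. Compound 2 therefore stands with the others, with no measured value separating it from them, and nothing can be said about any order among the three.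

The unmeasured compound 4, `CS(=O)(=O)c1ccc(Nc2ncc(F)c(Nc3nc4ccc(F)cc4s3)n2)cc1`, follows from compound 2 by one change: fluoro in place of hydrogen on an aromatic carbon. Going by the values given here, since no step between measured compounds with a known value exists here, the size of this step cannot be read off from the data. With compound 2 at the limit of > 60000 nM in this assay, at which 1 of the 3 values shown sits, compound 4 is expected to remain at or near a limit as well, with the step from compound 2 to compound 4 estimated as a number no higher from compound 2 to compound 4 (the limit leaves the size open), which is no more than the usual scatter. Compound 4 is thus estimated at 60000 nM, within a range from 15000 nM to 200000 nM, most likely reported again as a limit.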

Compound 4, half-maximal inhibitory concentration: > 50000 nM
Compound 4 gave a limit, no number; the forecaster's own chance of this, stated with the estimate: 75%; the middle value lies beyond the limit too.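

Going by these compounds alone, compound 2 and compound 4 both stand at limits in this assay, so no step for fluoro in place of hydrogen on an aromatic carbon can be read between them. The compounds shown leave open whether this change alters the read-out at all, since none of them gives a number: the limit of > 50000 nM in this assay, at which 3 of the 4 values shown sit.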